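Tert-Butyl in Place of Trifluoromethyl: an Expected Step

A few compounds are considered here, and "the series" means these few. Any claim that something is new, unique, unknown or untested is made for them only; others in the source may bear on it.

Of the compounds shown here, two have been measured in an in vitro functional assay on HEK293-A cells for antagonist activity at metabotropic glutamate receptor 5 (Rattus norvegicus), read by calcium flux; on this read-out lower numbers stand for stronger inhibition and higher numbers for weaker inhibition. Compound 1 `COc1cccc(NC(=O)c2cc(F)cc(C#N)c2)n1` gives 1510 nM in this assay. Compound 2 `N#Cc1cc(F)cc(C(=O)Nc2cccc(C(F)(F)F)c2)c1` gives 543 nM in this assay, the lower of the two numbers; the gap to compound 1 lies beyond the usual scatter of repeated measurements, so compound 2 is the stronger inhibitor of the pair.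

Compound 3 `CC(C)(C)c1cccc(NC(=O)c2cc(F)cc(C#N)c2)c1` has not been measured. It differs from compound 2 in one place: tert-butyl in place of trifluoromethyl on an aromatic carbon. Going by the values given here, no measured pair in this set shows the same change, so nothing here tells how large a step it brings. From compound 2 to compound 3 the expected step in this assay is a 1.3-fold higher number from compound 2 to compound 3 (0.11 log units; within the scatter), a change that is expected to stay within the scatter. The estimated value for compound 3 in this assay is 700 nM, with a range from 200 nM to 2500 nM.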

Compound 3, half-maximal inhibitory concentration: > 30000 nM
Compound 3 ended at the assay's limit; the forecaster's own chance of this, stated with the estimate: 5%; middle value at least 42-fold (1.63 log units) away from the limit.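

The place held by trifluoromethyl in compound 2 does not accept every group of the same size by count: 4 heavy atoms leave, 4 enter, neither group has a ring or any hydrogen-bond donors or acceptors, and the change to tert-butyl still brings an at least 55-fold higher number from compound 2 to compound 3 (1.74 log units; beyond the scatter) in this assay. Going by these compounds alone, compound 3 stands at a limit of the assay and not at a measured number, so the step gives only a lower bound: the limit of > 30000 nM in this assay, at which 1 of the 3 values shown sits. Compound 1 and compound 2 differ in more than one place and could not show this, whereas this pair shows how much can hang on the single group on this aromatic carbon.

The compounds shown leave open whether the loss is particular to tert-butyl or extends to other groups here. Going by these compounds, what a methyl group or a chlorine atom would give at this place also stays unknown.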